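A few compounds are considered here, and "the series" means these few. Any claim that something is new, unique, unknown or untested is made for them only; others in the source may bear on it.

Of the compounds shown here, two with the same core have been tested in an ADME assay on microsomes from liver (Homo sapiens) for metabolic stability, with a stated time of 10 min; a higher number here means that more of the compound is left, a lower number that less of the compound is left. Compound 1 `CCOc1nc(C)c(Nc2nc(Cl)cn([C@H](C)C3CC3)c2=O)cc1C` gives 81%, and compound 2 `Cc1cc(Nc2nc(Cl)cn([C@H](C)C3CC3)c2=O)c(C)nc1N(C)C` gives 29%, the lower of the two numbers. Among the measured compounds shown here, the single measured step, a number 52 percentage points lower from compound 1 to compound 2 (beyond the scatter), is large and comes from dimethylamino in place of ethoxy on an aromatic carbon. Compound 3 `Cc1cc(Nc2nc(Cl)cn([C@H](C)C3CC3)c2=O)c(C)nc1N1CCCC1` alters that same group, with pyrrolidin-1-yl in place of dimethylamino on an aromatic carbon. For the measured compounds named here, no measured step swaps one of these nitrogen-bearing groups for another, so the earlier step shows only that a change at this place can move the number a long way. The expected change is small and slightly downward, with no clear shift beyond the scatter, and in this assay the estimated step is a number 4 percentage points lower from compound 2 to compound 3 (within the scatter). Compound 3 is estimated at 25%, within a range from 8% to 50%.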

Compound 3, percent of the compound remaining: 26%
Beside the measured number, compound 3's estimate is 1 percentage points below it, within the range that was stated.
By their numbers in this assay, from the lowest: compounds 3 and 2 (each within the scatter of the next); then compound 1.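

In this assay, pyrrolidin-1-yl in place of dimethylamino gives a number 3 percentage points lower from compound 2 to compound 3 (within the scatter) at this place, so joining the amine into a five-membered ring leaves the number without a clear shift. Pyrrolidin-1-yl in place of ethoxy gives a number 55 percentage points lower from compound 1 to compound 3 (beyond the scatter) and this shows that the large step away from ethoxy is not tied to dimethylamino alone. Two different groups bound through nitrogen now both stand far from compound 1.

As far as these compounds go, whether this holds for other groups bound through nitrogen stays open, for instance a morpholine ring or an amine that still carries a hydrogen. From the compounds shown here alone, it is also open whether another group bound through oxygen, such as methoxy, would give a number close to that of ethoxy. Nothing available here explains the gap between ethoxy and these two nitrogen-bound groups.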